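From a Hydroxyphenyl to a Fluorophenyl Hydrazone

The source may hold more compounds than are shown below. What is called first, only, known or untested is meant among the compounds shown, and "the series" means these compounds.

Measured so far:
compound 1 `Cn1c(=O)c(=O)n(C2CCCC2)c2nc(N/N=C/c3ccc(Cl)cc3)ncc21` gives 8420 nM
compound 2 `Cn1c(=O)c(=O)n(C2CCCC2)c2nc(N/N=C/c3ccc(S(C)(=O)=O)cc3)ncc21` gives 26600 nM
compound 3 `Cn1c(=O)c(=O)n(C2CCCC2)c2nc(N/N=C/c3cccc(O)c3)ncc21` gives 36300 nM

In a functional assay on PC-3 cells (Homo sapiens) for antiproliferative activity, read by MTT assay (a higher number here means a weaker inhibitor, a lower number a stronger inhibitor), compound 3 stands at the highest of the three numbers. Its nearest neighbour is compound 2, and the step of a 1.4-fold higher number from compound 2 to compound 3 (0.14 log units; within the scatter) lies within the scatter, so the two cannot be ordered. The step of a 4.3-fold higher number from compound 1 to compound 3 (0.63 log units; beyond the scatter) lies beyond the scatter, and the step of a 3.2-fold higher number from compound 1 to compound 2 (0.50 log units; beyond the scatter) likewise, so compound 1 gives the lowest number of the three.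

Compound 4 `Cn1c(=O)c(=O)n(C2CCCC2)c2nc(N/N=C/c3ccccc3F)ncc21` differs from compound 3 in one place: 2-fluorophenyl in place of 3-hydroxyphenyl on a carbon with a double bond to nitrogen. For the measured compounds named here, two measured steps bear on this. The step of a 4.3-fold higher number from compound 1 to compound 3 (0.63 log units; beyond the scatter) shows that exchanging a halogen-bearing aryl for the 3-hydroxyphenyl raised the number modestly, whereas the step of a 1.4-fold higher number from compound 2 to compound 3 (0.14 log units; within the scatter) shows no change beyond the scatter. Compound 4 again carries a halogen on its aryl group, though as 2-fluorophenyl rather than 4-chlorophenyl, so a modest move back toward the number of compound 1 is expected, with the size uncertain. For compound 4 the estimate is 15000 nM, within 5000 nM to 45000 nM. This estimate corresponds to an expected step of a 2.4-fold lower number from compound 3 to compound 4 (0.38 log units; beyond the scatter).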

Compound 4, half-maximal inhibitory concentration: 27600 nM
For compound 4 the middle estimate is 1.8-fold (0.26 log units) below the measured one; low and high end bracket the measured number.
By their numbers in this assay, from the lowest: compound 1; then compounds 2, 4 and 3 (each within the scatter of the next).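

In this assay, 2-fluorophenyl in place of 3-hydroxyphenyl gives a step within the scatter (a 1.3-fold lower number from compound 3 to compound 4 (0.12 log units; within the scatter)), and 2-fluorophenyl in place of 4-(methylsulfonyl)phenyl does the same (a 1.0-fold higher number from compound 2 to compound 4 (0.02 log units; within the scatter)), so compounds 2, 3 and 4 cannot be ordered although their aryl groups differ. The entering group has 0 hydrogen-bond donors and 0 hydrogen-bond acceptors, so the hydrogen-bond donor and acceptor of 3-hydroxyphenyl are not needed for compound 3 to read as it does in this set. A halogen on the aryl group is also not enough to reach the number of compound 1, as 2-fluorophenyl in place of 4-chlorophenyl gives a step beyond the scatter (a 3.3-fold higher number from compound 1 to compound 4 (0.52 log units; beyond the scatter)), and compound 4 thus goes against any simple link between a halogen and a lower number.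

Nothing measured here accounts for these steps. The compounds shown leave open whether the lower number of compound 1 goes with the chlorine or with its place on the ring, which 4-fluorophenyl and 2-chlorophenyl would separate, and how an aryl group carrying an amine or a carboxylic acid would read.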